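Amine variation on the acrylamide side chain

This account rests on a few compounds, and the source may have more. Where it says the series, first, only, none or still open, it means among the compounds named here.

Compound 1 `O=C(/C=C/CN1CCCC1)Nc1cc2c(N3CCCc4ccccc43)ncnc2cc1O[C@@H]1CCOC1` is measured in a functional assay on PC-3 cells (Homo sapiens) for antiproliferative activity, read by MTT assay, with a stated time of 72 h (on this read-out higher numbers stand for weaker inhibition and lower numbers for stronger inhibition), where compound 1 gives 5780 nM. Compound 2 `CN1CCN(C/C=C/C(=O)Nc2cc3c(N4CCCc5ccccc54)ncnc3cc2O[C@@H]2CCOC2)CC1` carries the other amine on the chain and in this assay compound 2 gives 9450 nM. The one step between them is a 1.6-fold higher number from compound 1 to compound 2 (0.21 log units; within the scatter), so on the two numbers shown compound 2 differs from compound 1 only within the scatter, and neither can be set above the other.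

Compound 3 `O=C(/C=C/CN1CCC(CO)CC1)Nc1cc2c(N3CCCc4ccccc43)ncnc2cc1O[C@@H]1CCOC1` is not yet measured. It differs from compound 2 by 4-(hydroxymethyl)piperidin-1-yl in place of 4-methylpiperazin-1-yl on a saturated chain carbon bound to a double-bonded chain carbon. Among the compounds with values here, the only measured step that bears on this change is the exchange of the amine at the same place, a 1.6-fold higher number from compound 1 to compound 2 (0.21 log units; within the scatter), which stayed within the scatter. On that basis the expectation for compound 3 in this assay is a step of a 1.3-fold lower number from compound 2 to compound 3 (0.10 log units; within the scatter), that is no change beyond the scatter in either direction. Within the data shown here, compound 3 is therefore estimated at 7500 nM, with a range from 3000 nM to 20000 nM, the width reflecting that only one earlier step of this kind is available.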

Compound 3, half-maximal inhibitory concentration: 5460 nM
Estimate against measurement, compound 3: 1.4-fold (0.14 log units) above; measured number inside the range.
By their numbers in this assay, from the lowest: compounds 3, 1 and 2 (each within the scatter of the next).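

In this assay, a third amine on the saturated chain carbon bound to a double-bonded chain carbon gives a 1.7-fold lower number from compound 2 to compound 3 (0.24 log units; within the scatter) and a 1.1-fold lower number from compound 1 to compound 3 (0.02 log units; within the scatter), so pyrrolidin-1-yl, 4-methylpiperazin-1-yl and 4-(hydroxymethyl)piperidin-1-yl now all stand within the scatter of one another and none can be set above the others. Within the data shown here, the exchange of 4-methylpiperazin-1-yl for 4-(hydroxymethyl)piperidin-1-yl adds a hydrogen-bond donor and replaces one ring nitrogen with carbon, and this larger change in the group also stays within the scatter, which the single earlier step could not show. Nothing at hand explains why the numbers stay this close, so the flat picture at this position stands as an observation only.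

From the compounds shown here alone, it stays open whether an open-chain amine such as dimethylamino, or a ring with oxygen such as morpholin-4-yl, would also stay within the scatter of these three compounds. Also open, going by these compounds, is whether a longer chain between the double bond and the amine, or a carboxylic acid in place of the hydroxymethyl group on the piperidine, would move the number beyond the scatter.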